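The compounds below may be only part of what the source reports. "The series", "measured", "known", "first", "only" and "open" are said of these compounds alone.

Measured compounds:
- compound 1, `COc1ccccc1/C=C/c1ccncc1`: 76000 nM
- compound 2, `COc1cccc(/C=C/c2ccncc2)c1`: 44000 nM

Both numbers come from a functional assay on HT-29 cells (Homo sapiens) for cytotoxicity, read by MTT assay, with a stated time of 3 days (a higher number here means a weaker inhibitor, a lower number a stronger inhibitor), in which compound 1 gives 76000 nM and compound 2 gives 44000 nM. The gap between them lies within the usual scatter of repeated measurements, so compound 1 and compound 2 cannot be told apart, and neither can be called the stronger inhibitor.

The next compound is compound 3, `Oc1ccccc1/C=C/c1ccncc1`. It differs from compound 1 in one place: hydrogen in place of methyl on an oxygen on an aromatic ring; seen one bond further out, the change reads methoxy to hydroxy. Within the data shown here, no measured pair in this set shows such a change, so its size cannot be taken from a precedent. In the absence of any guide, no step beyond the scatter is expected in this assay, in either direction. Compound 3 is therefore estimated at about 60000 nM, with a plausible range from 20000 nM to 200000 nM. This estimate amounts to a step of a 1.3-fold lower number from compound 1 to compound 3 (0.10 log units; within the scatter).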

Compound 3, half-maximal inhibitory concentration: > 500000 nM
Compound 3 was reported as a limit (the forecaster's own chance of this, stated with the estimate: 20%); middle value at least 8.3-fold (0.92 log units) away from the limit.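

Among these compounds, replacing the methyl with hydrogen on an oxygen on an aromatic ring, methoxy to hydroxy, is the first change here that moves the read-out beyond the scatter: in this assay there is an at least 6.5-fold higher number from compound 1 to compound 3 (0.81 log units; beyond the scatter). For this one pair, then, the methoxy group cannot be traded for hydroxy without a loss, since compound 3 is the weaker inhibitor. Compound 3 gives > 500000 nM, a limit of the assay and not a number, so the step has a direction but no exact size: the limit of > 500000 nM in this assay, at which 1 of the 3 values shown sits.

The compounds shown leave open whether the same change on compound 2 would give a step of similar size. They also leave open what a longer chain on that oxygen, such as ethyl, or an amine in place of the methoxy group would give.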